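The compounds below may be only part of what the source reports. "The series", "measured", "known", "first", "only" and "open" are said of these compounds alone.

- Compound 1 `CCCCCCc1ccc(-c2c(C)[nH]c(=O)n2C2CCCCC2)cc1`: 13700 nM
- Compound 2 `CCCCCCCc1ccc(-c2c(C)[nH]c(=O)n2C2CCCCC2)cc1`: 8700 nM
- Compound 3 `CCCCCCCCc1ccc(-c2c(C)[nH]c(=O)n2C2CCCCC2)cc1`: 10300 nM

These values come from a functional assay on brain (Rattus norvegicus, strain Wistar) for inhibition; on this read-out higher numbers stand for weaker inhibition and lower numbers for stronger inhibition. There, compound 3, at 10300 nM, lies within the scatter of both compound 1 and compound 2, so the three cannot be ordered. Compound 4 `CCCCCCCCCCCCc1ccc(-c2c(C)[nH]c(=O)n2C2CCCCC2)cc1` extends the chain of compound 3: butyl in place of hydrogen on a saturated chain carbon, eight bonds along the chain from an aromatic carbon. The measured steps that bear on this are the shorter chain additions: a 1.6-fold lower number from compound 1 to compound 2 (0.20 log units; within the scatter), a 1.2-fold higher number from compound 2 to compound 3 (0.07 log units; within the scatter) and a 1.3-fold lower number from compound 1 to compound 3 (0.12 log units; within the scatter). All three lie within the scatter. Butyl is a larger addition than any of these, so the extrapolation is uncertain, but the data give no direction for a change. The expected result is a 1.1-fold lower number from compound 3 to compound 4 (0.06 log units; within the scatter), with no change beyond the scatter. For compound 4 the estimated value is 9000 nM, with an expected range of 3500 nM to 25000 nM.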

Compound 4, half-maximal inhibitory concentration: > 100000 nM
Compound 4: no number, only a limit (the forecaster's own chance of this, stated with the estimate: 15%); middle value at least 11-fold (1.04 log units) from the limit.
By their numbers in this assay, from the lowest: compounds 2, 3 and 1 (each within the scatter of the next). At a limit, above all of these: compound 4.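

Compound 4 stands at a limit, not a number, in this assay: the limit of > 100000 nM in this assay, at which 1 of the 4 values shown sits. The shorter chain additions stayed within the scatter, but this longer chain gives an at least 9.7-fold higher number from compound 3 to compound 4 (0.98 log units; beyond the scatter), alongside an at least 11-fold higher number from compound 2 to compound 4 (1.06 log units; beyond the scatter) and an at least 7.2-fold higher number from compound 1 to compound 4 (0.86 log units; beyond the scatter). Chain length at this position therefore does matter: compound 4 shows weaker inhibition than each of compounds 1, 2 and 3, a separation those three never showed among themselves.

Going by these compounds, how far compound 4 lies past its limit stays open. So does the length at which inhibition falls away, which a nonyl or decyl chain, or a chain ending in a carboxylic acid, could help to settle.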